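The source may report more compounds than this note shows. Statements on the series, on what has been measured and on what is new or still open speak of the compounds shown alone.

Compound 2, with the structure `CCOC(=O)CCCCCOc1cccc(CN(C(=O)c2ccc(-c3cccc(C(F)(F)F)c3)cc2)C(C)C)c1`, has been tested in an ADME assay on HepG2 cells (Homo sapiens) for cytotoxicity, read by CellTiter-Glo and resazurin assay, with a stated time of 72 h; a lower number here means that less compound is needed, a higher number that more compound is needed for the effect. In this assay compound 2 gives only a limit, > 26000 nM, and not a number. Among the compounds with values here, its one measured neighbour is compound 1, with the structure `CCOC(=O)CCCCCOc1cccc(CN(C(=O)c2ccc(-c3cccc(-c4ccccc4)c3)cc2)C(C)C)c1`, which carries phenyl where compound 2 carries trifluoromethyl. In this assay compound 1 likewise gives only a limit, > 26000 nM. Both compounds sit at the limit of > 26000 nM in this assay, at which 2 of the 2 values shown sit, so the step that the two limits leave unreadable from compound 1 to compound 2 cannot be read, and the size of any change between them stays hidden. Compound 3, with the structure `CCOC(=O)CCCCCOc1cccc(CN(C(=O)c2ccc(-c3cccc([N+](=O)[O-])c3)cc2)C(C)C)c1`, has not yet been measured. The change from compound 2 to compound 3 is nitro in place of trifluoromethyl on an aromatic carbon. Within the data shown here, the only measured step, from compound 1 to compound 2, has no readable size, so there is no basis for expecting a step beyond the scatter in this assay; the expectation is simply that compound 3 stays at the same limit as its two neighbours. The expected step from compound 2 to compound 3 is a number no higher from compound 2 to compound 3 (the limit leaves the size open). Compound 3 is expected to give about 26000 nM, within a range from 13000 nM to 60000 nM.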

Compound 3, half-maximal effective concentration: > 26000 nM
Compound 3: a limit, no number (the forecaster's own chance of this, stated with the estimate: 85%); the middle value lies on the limit itself.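

Compound 3, like compound 1 and compound 2, gives only a limit and not a number, so none of the steps among these three compounds can be read in this assay: the limit of > 26000 nM in this assay, at which 3 of the 3 values shown sit.

The compounds shown leave open whether phenyl, trifluoromethyl and nitro differ at all in this assay, and what concentration each compound would need for the effect.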